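The compounds below may be only part of what the source reports. "The series", "measured", "known", "first", "only" and "open" are said of these compounds alone.

Three compounds built on one shared core, a ring system carrying a phenyl group, differ only in how long a saturated carbon chain runs from the aromatic nitrogen to a thioamide end group. In a functional assay on the whole organism (stomach) for inhibition, with Rattus norvegicus as the target, at a dose of 100 mg/kg by the intraduodenal route (on this read-out higher numbers stand for more inhibition at the one dose given (going by the name of the read-out) and lower numbers for less inhibition), compound 1, `N=C(S)CCCCCCn1nc(-c2ccccc2)ccc1=O`, gives 33.9%. Compound 2, `N=C(S)CCCCCn1nc(-c2ccccc2)ccc1=O`, gives 91.4%, and compound 3, `N=C(S)CCn1nc(-c2ccccc2)ccc1=O`, gives 53.7% in this assay. Taking one carbon out of the chain, that is a group of 3 heavy atoms (1 carbon, 1 nitrogen, 1 sulfur; no ring) in place of a group of 4 heavy atoms (2 carbon, 1 nitrogen, 1 sulfur; no ring), on a saturated chain carbon, five bonds along the chain from an aromatic nitrogen, made the step of a number 57.5 percentage points higher from compound 1 to compound 2 (beyond the scatter). Shortening the chain much further, (a group of 3 heavy atoms (1 carbon, 1 nitrogen, 1 sulfur; no ring) in place of a group of 7 heavy atoms (5 carbon, 1 nitrogen, 1 sulfur; no ring), on a saturated chain carbon, two bonds along the chain from an aromatic nitrogen), gave a number 19.8 percentage points higher from compound 1 to compound 3 (beyond the scatter), while a number 37.7 percentage points lower from compound 2 to compound 3 (beyond the scatter). Compound 4, `N=C(S)Cn1nc(-c2ccccc2)ccc1=O`, has not been measured in this assay. It stands to compound 3 as compound 2 stands to compound 1: the same kind of change, (a group of 3 heavy atoms (1 carbon, 1 nitrogen, 1 sulfur; no ring) in place of a group of 4 heavy atoms (2 carbon, 1 nitrogen, 1 sulfur; no ring), on a saturated chain carbon bound to an aromatic nitrogen), but here the place is the carbon bound directly to the aromatic nitrogen rather than five bonds along the chain from it, and the core it sits on differs by a group of 3 heavy atoms (1 carbon, 1 nitrogen, 1 sulfur; no ring) in place of a group of 7 heavy atoms (5 carbon, 1 nitrogen, 1 sulfur; no ring), on a saturated chain carbon, two bonds along the chain from an aromatic nitrogen. Among the compounds with values here, the one earlier step of this kind was large and upward, yet the next shortening, from compound 2 to compound 3, went the other way, so no single direction holds across these three compounds. The step is expected to be smaller than before, roughly a number 11.7 percentage points lower from compound 3 to compound 4 (beyond the scatter). Compound 4 is estimated to give 42% in this assay, with a wide band from 15% to 75% reflecting that uncertainty.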

Compound 4, a percentage reported as inhibition, in the whole organism at one dose (the size of the read-out at that dose, not a potency): 5.5%
Estimate against measurement, compound 4: 36.5 percentage points above; the measured number lies below the stated range.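

In this assay, shortening the chain at the saturated chain carbon bound to an aromatic nitrogen gave a number 48.2 percentage points lower from compound 3 to compound 4 (beyond the scatter), so the same kind of shortening that raised the number on the longer chain lowered it here: the same change on two cores in this assay, a number 57.5 percentage points higher (beyond the scatter) from compound 1 to compound 2 and a number 48.2 percentage points lower (beyond the scatter) from compound 3 to compound 4, 105.7 percentage points apart, beyond the scatter of two such steps. The larger shortening, taken from compound 2, gave a number 85.9 percentage points lower from compound 2 to compound 4 (beyond the scatter), and it too failed to match its earlier counterpart: the same change on two cores in this assay, a number 19.8 percentage points higher (beyond the scatter) from compound 1 to compound 3 and a number 85.9 percentage points lower (beyond the scatter) from compound 2 to compound 4, 105.7 percentage points apart, beyond the scatter of two such steps. This shows that in this series the result of such a change cannot simply be carried from one core to another, in size or in direction, but it does not show why the steps differ, and with single readings at one dose in a whole animal it says nothing about potency.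

As far as these compounds go, what stays open is how the number runs for chains of a length between those of compound 3 and compound 2, and whether a longer chain than that of compound 1 would lower it further. From the compounds shown here alone, it is also open whether an amide, a carboxylic acid or an amine at the chain end would show the same rise and fall with chain length.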